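Amine variation on the shared core: compound 3 estimate

This account rests on a few compounds, and the source may have more. Where it says the series, first, only, none or still open, it means among the compounds named here.

Measured so far:
compound 1, `CCCC(CCC)Nc1cc(C)nc2c(-c3cnc(N(C)C)cc3C)c(C)nn12`, 4.8 nM
compound 2, `CCCN(CC1CC1)c1cc(C)nc2c(-c3cnc(N(C)C)cc3C)c(C)nn12`, 2.6 nM

In an assay on CHO cells for binding affinity to corticotropin-releasing factor receptor 1 (Homo sapiens) (on this read-out higher numbers stand for weaker inhibition and lower numbers for stronger inhibition), compound 2 gives the lowest of the two numbers, with compound 1 nearest at a 1.8-fold lower number from compound 1 to compound 2 (0.27 log units; within the scatter), a gap within the scatter, so no order between the two is claimed.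

Compound 3, `CCCCN(CCCC)c1cc(C)nc2c(-c3cnc(N(C)C)cc3C)c(C)nn12`, carries dibutylamino in place of (cyclopropylmethyl)(propyl)amino on an aromatic carbon.

Within the data shown here, the only measured step that bears on this change is the exchange of one amino substituent for another at the same aromatic carbon, a 1.8-fold lower number from compound 1 to compound 2 (0.27 log units; within the scatter), which stayed within the scatter. On that basis no step beyond the scatter is expected, and the estimated step is a 1.2-fold higher number from compound 2 to compound 3 (0.06 log units; within the scatter).

Compound 3 is therefore expected to give about 3 nM in this assay, with a range from 1.2 nM to 8 nM.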

Compound 3, inhibition constant: 4.2 nM
Beside the measured number, compound 3's estimate is 1.4-fold (0.15 log units) below it; the range from low to high includes it.
By their numbers in this assay, from the lowest: compounds 2, 3 and 1 (each within the scatter of the next).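

In this assay, dibutylamino in place of (cyclopropylmethyl)(propyl)amino on the aromatic carbon gives a 1.6-fold higher number from compound 2 to compound 3 (0.21 log units; within the scatter), and dibutylamino in place of (1-propylbutyl)amino gives a 1.1-fold lower number from compound 1 to compound 3 (0.06 log units; within the scatter). Across these compounds, then, removing the three-membered ring and changing the heavy-atom count of the amino group by one leaves the number within the scatter, so this position accommodates an acyclic dialkylamino group as well as the two earlier amino groups without a readable difference. No independent measurement bears on this result.

All three amino groups shown carry only carbon substituents on the nitrogen, so it remains open whether a bis(2-methoxyethyl)amino group, with ether oxygens in its chains, would stay in the same range. On these data alone, a much shorter group such as dimethylamino at this position is equally open, and it would test how far the chains can be cut back.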